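Methylsulfanyl in place of methoxy on an aromatic carbon

A few compounds are considered here, and "the series" means these few. Any claim that something is new, unique, unknown or untested is made for them only; others in the source may bear on it.

In a functional assay on MCF7 cells (Homo sapiens) for inhibition, read by resazurin assay, with a stated time of 72 h (on this read-out lower numbers stand for stronger inhibition and higher numbers for weaker inhibition), compound 1 `COc1cc(N2C(=O)CC2c2ccc(SC)cc2)cc(OC)c1OC` gives 67 nM, compound 2 `C=CC1C(=O)N(c2cc(OC)c(OC)c(OC)c2)C1c1ccc(SC)cc1` gives 51 nM and compound 3 `COc1ccc(C2C(Oc3ccccc3)C(=O)N2c2cc(OC)c(OC)c(OC)c2)cc1` gives 23 nM, the lowest of the three numbers and beyond the scatter of both others. Compound 4 `COc1cc(N2C(=O)C(Oc3ccccc3)C2c2ccc(SC)cc2)cc(OC)c1OC` differs from compound 3 by methylsulfanyl in place of methoxy on an aromatic carbon. For the measured compounds named here, the only measured step, a 1.3-fold lower number from compound 1 to compound 2 (0.12 log units; within the scatter), is a different change, vinyl in place of hydrogen, and lies within the scatter. Going by the values given here, compound 1 and compound 2 carry methylsulfanyl but differ from compound 3 in more than one place, so no measured step isolates this change. No shift beyond the scatter is therefore expected in this assay, and the expected step is a 1.3-fold higher number from compound 3 to compound 4 (0.12 log units; within the scatter). For compound 4 the estimate is 30 nM, with an expected range of 10 nM to 90 nM.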

Compound 4, half-maximal inhibitory concentration: 152 nM
Beside the measured number, compound 4's estimate is 5.1-fold (0.70 log units) below it; measured number outside the range, above it.
By their numbers in this assay, from the lowest: compound 3; then compounds 2 and 1 (each within the scatter of the next); then compound 4.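

In this assay, for the compounds shown here, the change is isolated for the first time (a 6.6-fold higher number from compound 3 to compound 4 (0.82 log units; beyond the scatter)), so with phenoxy on the saturated ring carbon, 4-(methylsulfanyl)phenyl and 4-methoxyphenyl are not interchangeable. Within the methylsulfanyl compounds, phenoxy also carries the higher number, both in place of hydrogen (a 2.3-fold higher number from compound 1 to compound 4 (0.36 log units; beyond the scatter)) and in place of vinyl (a 3.0-fold higher number from compound 2 to compound 4 (0.47 log units; beyond the scatter)). No available data explain either shift.

On these data alone, whether the methylsulfanyl step holds with hydrogen or vinyl in place of phenoxy remains open. So does how ethylsulfanyl or dimethylamino would read at this position.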